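A Hydroxyl Replaces Fluorine on the Amide Aryl Group

The compounds below may be only part of what the source reports. "The series", "measured", "known", "first", "only" and "open" are said of these compounds alone.

Measured so far:
Compound 1 `COc1ccc(-n2nc(C(=O)Nc3ccc(C)cc3)nc2-c2cc(OC)c(OC)c(OC)c2)cc1`: 42%
Compound 2 `COc1ccc(-n2nc(C(=O)Nc3cccc(F)c3)nc2-c2cc(OC)c(OC)c(OC)c2)cc1`: 53%

In a functional assay on the whole organism for inhibition, with Rattus norvegicus as the target, read by paw edema, with stated times of 30 min and 5 h, at a dose of 0.28 mmol/kg by the oral route (a higher number here means more inhibition at the dose given (going by the name of the read-out), a lower number less inhibition), compound 2 gives 53%, the higher of the two numbers, while compound 1 gives 42%. Going by the values given here, the one measured step, a number 11 percentage points higher from compound 1 to compound 2 (beyond the scatter), shows that changing the aryl group on the amide nitrogen moves this assay modestly. Compound 3 `COc1ccc(-n2nc(C(=O)Nc3ccc(O)cc3)nc2-c2cc(OC)c(OC)c(OC)c2)cc1` differs from compound 2 in exactly that place: 4-hydroxyphenyl in place of 3-fluorophenyl on an amide-type nitrogen. Among the compounds with values here, no measured step covers this particular exchange, so only a small shift, possibly within the scatter, is expected: a number 6 percentage points lower from compound 2 to compound 3 (within the scatter). Compound 3 is therefore estimated at 47%, with a likely range from 32% to 62%.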

Compound 3, a percentage reported as inhibition, in the whole organism at one dose (the size of the read-out at that dose, not a potency): 27%
The estimate for compound 3 lay 20 percentage points above the measured number; the whole stated range lies above it.
By their numbers in this assay, from the lowest: compound 3; then compound 1; then compound 2.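

The aryl group on the amide nitrogen can lower the number as well as raise it: in this assay there is a number 26 percentage points lower from compound 2 to compound 3 (beyond the scatter) and compound 3 sits below both earlier compounds. With only hydroxy in place of methyl on an aromatic carbon, there is also a number 15 percentage points lower from compound 1 to compound 3 (beyond the scatter), a drop seen without fluorine in the comparison. No measurement here accounts for this drop. From the compounds shown here alone, whether hydroxy alone carries this loss stays open. An amine or a carboxylic acid on the same aromatic carbon would help to show how specific it is.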